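This account rests on a few compounds, and the source may have more. Where it says the series, first, only, none or still open, it means among the compounds named here.

Compound 1 `CC1CCN(C2CCN(S(=O)(=O)c3ccc(F)cc3F)CC2)CC1`: > 5000 nM
Compound 2 `Cc1ccc(-c2ccccc2S(=O)(=O)N2CCC(N3CCC(C)CC3)CC2)cc1`: > 5000 nM
Compound 3 `Cc1ccc(-c2cccc(S(=O)(=O)N3CCC(N4CCC(C)CC4)CC3)c2)cc1`: > 5000 nM

Of the compounds shown here, three have been tested in an ADME assay on HCT-116 cells (Homo sapiens) for cytotoxicity, read by CellTiter-Glo, with a stated time of 72 h; on this read-out lower numbers stand for stronger inhibition and higher numbers for weaker inhibition. Compound 1 gives > 5000 nM, which is a limit of the assay rather than a number. Compound 2 gives > 5000 nM, also a limit. Compound 3 gives > 5000 nM, again a limit. Compound 1 therefore stands at the limit together with the two others: the limit of > 5000 nM in this assay, at which 3 of the 3 values shown sit. Going by the values given here, no measured pair differs in only one place, so no single step in this assay can be read from what has been measured.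

Compound 4 `CC1CCN(C2CCN(S(=O)(=O)c3ccc(Cl)c(Cl)c3)CC2)CC1` differs from compound 1 in one place: 3,4-dichlorophenyl in place of 2,4-difluorophenyl on a sulfonyl sulfur. Among the compounds with values here, with every measured value sitting at the limit, there is no measured step on which to base a size or direction. The step in this assay is expected to be a step that the limit leaves unreadable from compound 1 to compound 4, that is, none beyond the scatter. Compound 4 is expected most likely to be reported only as a limit as well. Compound 4 is estimated at 9000 nM, within 3000 nM to 40000 nM.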

Compound 4, half-maximal inhibitory concentration: > 5000 nM
Compound 4: only a limit was reported; the forecaster's own chance of this, stated with the estimate: 80%; the middle value does not contradict the limit.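

In this assay compound 4 gives > 5000 nM, which is a limit and not a number. Going by these compounds alone, compound 1 also sits at a limit, so no step between compound 1 and compound 4 can be read. What the compounds shown leave open is how strongly any of them inhibits, since all share one ceiling: the limit of > 5000 nM in this assay, at which 4 of the 4 values shown sit.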